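The compounds below may be only part of what the source reports. "The series", "measured", "known", "first", "only" and "open" are said of these compounds alone.

Measured compounds:
- compound 1, `OC[C@H]1O[C@@H](n2cnc3c(NCc4ccc(Br)cc4)ncnc32)[C@H](O)[C@@H]1O`: 47400 nM
- compound 2, `OC[C@H]1O[C@@H](n2cnc3c(NCc4cc(O)cc(O)c4)ncnc32)[C@H](O)[C@@H]1O`: "not determined" (no result reported) in a functional assay on HL-60 cells (Homo sapiens) for antiproliferative activity, with a stated time of 72 h; on this read-out lower numbers stand for stronger inhibition and higher numbers for weaker inhibition

Among the compounds with values here, compound 1 carries the only number in this assay; compound 2 gives no value to set against it. Compound 3, `Cc1ccc(O)c(CNc2ncnc3c2ncn3[C@@H]2O[C@H](CO)[C@@H](O)[C@H]2O)c1`, is not yet measured. Its difference from compound 1 is 2-hydroxy-5-methylphenyl in place of 4-bromophenyl on a saturated chain carbon bound to a nitrogen on an aromatic ring. Within the data shown here, no step between measured compounds is available, so the size of the change cannot be calibrated from the series. Given the weak starting point of compound 1, a step no larger than the scatter, in either direction, is expected for compound 3: a 1.2-fold lower number from compound 1 to compound 3 (0.07 log units; within the scatter). Compound 3 is therefore estimated at 40000 nM, within 10000 nM to 150000 nM.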

Compound 3, half-maximal inhibitory concentration: 15000 nM
Estimate against measurement, compound 3: 2.7-fold (0.43 log units) above; the measured number falls inside the stated range.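

In this assay, within the data shown here, 2-hydroxy-5-methylphenyl in place of 4-bromophenyl gives a 3.2-fold lower number from compound 1 to compound 3 (0.50 log units; beyond the scatter), the first step that can be sized and one beyond the scatter. This position therefore responds to the aryl group, and bromine is not needed for activity in this pair. The change swaps the whole group at once, so the step belongs to the combined replacement, and nothing available bears on its cause.

As far as these compounds go, whether the hydroxy or the methyl alone carries the step stays open. So does the outcome with an aminomethyl or carboxylic acid group on the phenyl ring, or with a longer chain in place of the benzyl.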